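The compounds below may be only part of what the source reports. "The series", "measured", "known", "first", "only" and "open" are said of these compounds alone.

Compound 3 `FC(F)(F)c1ccc(CSc2nc(N3CCCCC3)c3ccccc3n2)cc1` gives 25500 nM in a functional assay on PC-3 cells (Homo sapiens) for cytotoxicity, read by MTT assay, with a stated time of 72 h; on this read-out higher numbers stand for weaker inhibition and lower numbers for stronger inhibition. Compound 1 `CCCCCCCCCCCCNc1nc(SCc2ccc(C(F)(F)F)cc2)nc2ccccc12` gives 26000 nM in this assay, a figure within the usual scatter of that for compound 3. Compound 2 `CCCCCCCCCCCCCCNc1nc(SCc2ccc(C(F)(F)F)cc2)nc2ccccc12` reaches only a limit of the assay, > 50000 nM. For the measured compounds named here, the single measured step, an at least 1.9-fold higher number from compound 1 to compound 2 (0.28 log units; that floor lies within the scatter), lengthens a long chain and ends at the limit of > 50000 nM in this assay, at which 1 of the 3 values shown sits. Compound 4 `Cc1ccccc1Nc1nc(SCc2ccc(C(F)(F)F)cc2)nc2ccccc12` differs from compound 3 by (2-methylphenyl)amino in place of piperidin-1-yl on an aromatic carbon. Going by the values given here, no measured step touches that kind of change, so the only guide is that the three values so far lie close together or at the limit. For compound 4 the expected step is a 1.0-fold lower number from compound 3 to compound 4 (0.01 log units; within the scatter), nothing beyond the scatter. Compound 4 is therefore estimated at 25000 nM, between 8000 nM and 60000 nM, with a real chance that only a limit is reported.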

Compound 4, half-maximal inhibitory concentration: 36900 nM
The estimate for compound 4 lay 1.5-fold (0.17 log units) below the measured number; measured number inside the range.
By their numbers in this assay, from the lowest: compounds 3, 1 and 4 (each within the scatter of the next). At a limit, above all of these: compound 2.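

Putting (2-methylphenyl)amino in place of piperidin-1-yl on this aromatic carbon replaces a non-aromatic ring with an aromatic one and adds a hydrogen-bond donor, yet this assay records only a 1.4-fold higher number from compound 3 to compound 4 (0.16 log units; within the scatter). Both groups are therefore accepted at this position with no change beyond the scatter. Only compound 2 remains at a limit: the limit of > 50000 nM in this assay, at which 1 of the 4 values shown sits.

Still open, as far as these compounds go, is whether a plain amino group or a morpholine ring on this carbon would shift the number. The contribution of the methyl group on the new ring also remains unresolved.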